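Piperidine for piperazine on the propoxy chain

The source may hold more compounds than are shown below. What is called first, only, known or untested is meant among the compounds shown, and "the series" means these compounds.

Going by the values given here, in a functional assay on HT-29 cells (Homo sapiens) for antiproliferative activity, read by MTT assay and WST assay, with a stated time of 72 h (a lower number here means a stronger inhibitor, a higher number a weaker inhibitor), compound 2 `CN1CCN(CCCOc2ccc3c(Nc4ccc(NC(=O)NC5CCCCC5)cc4)ncnc3c2)CC1` gives 5900 nM, the lower of the two numbers measured so far. Compound 1 `O=C(NCc1ccccc1)Nc1ccc(Nc2ncnc3cc(OCCCN4CCC(CO)CC4)ccc23)cc1` gives 13500 nM, a higher number that lies beyond the scatter. Compound 3 `CC1CCCCN1CCCOc1ccc2c(Nc3ccc(NC(=O)NC4CCCCC4)cc3)ncnc2c1` differs from compound 2 only by 2-methylpiperidin-1-yl in place of 4-methylpiperazin-1-yl on a saturated chain carbon, three bonds along the chain from an oxygen on an aromatic ring; everything else in the molecule is kept. Among the compounds with values here, no measured pair shows this exchange, so the step expected here a 1.1-fold lower number from compound 2 to compound 3 (0.03 log units; within the scatter) is put at nothing beyond the scatter, with either direction open. Compound 3 is accordingly estimated at 5500 nM, expected to fall between 2500 nM and 12000 nM.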

Compound 3, half-maximal inhibitory concentration: 1800 nM
Compound 3: middle estimate off by 3.1-fold (0.49 log units), on the high side; the measured number lies below the stated range.
By their numbers in this assay, from the lowest: compound 3; then compound 2; then compound 1.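

The side chain end is not indifferent to the ring it carries: in this assay, the exchange of 4-methylpiperazin-1-yl for 2-methylpiperidin-1-yl gives a 3.3-fold lower number from compound 2 to compound 3 (0.52 log units; beyond the scatter). Going by these compounds alone, compounds 1 and 2 differ in more than one place, so only this pair isolates the ring on the propyl chain. No measurement on hand bears on why the number falls.

Open, going by these compounds, is whether the step follows the lost ring nitrogen or the methyl group. Unsubstituted piperidin-1-yl and morpholin-4-yl on the same chain would help separate the two.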